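The source may hold more compounds than are shown below. What is called first, only, known or untested is meant among the compounds shown, and "the series" means these compounds.

The three measured compounds share one core and differ only in the group on a saturated chain carbon bound to an oxygen next to a carbonyl group. Compound 1 `C[C@@H]1CN(C(=O)c2nc(Nc3cc(C4CC4)[nH]n3)c3cc(Cl)ccc3n2)CCN1C(=O)OCc1ccccc1` carries phenyl there and gives 74% in an assay for inhibition of serine/threonine-protein kinase PAK 4 (Homo sapiens), read by FRET and Z'-LYTE, with a stated time of 60 min, tested at 5 uM, in the presence of a further agent that is not named here; a higher number here means a stronger effect of the compound at the concentration tested, a lower number a weaker effect. Compound 2 `COC(=O)N1CCN(C(=O)c2nc(Nc3cc(C4CC4)[nH]n3)c3cc(Cl)ccc3n2)C[C@H]1C` carries hydrogen there and gives 89.6% in this assay. Compound 3 `C[C@@H]1CN(C(=O)c2nc(Nc3cc(C4CC4)[nH]n3)c3cc(Cl)ccc3n2)CCN1C(=O)OCOC(=O)C(C)(C)C` carries ((tert-butyl)carbonyl)oxy there and gives 24.1% in this assay, the lowest of the three numbers; its nearest neighbour is compound 1 and its furthest compound 2, both beyond the scatter. The steps into compound 3 were a number 49.9 percentage points lower from compound 1 to compound 3 (beyond the scatter) and a number 65.5 percentage points lower from compound 2 to compound 3 (beyond the scatter), so the arrival of ((tert-butyl)carbonyl)oxy on that carbon lowered the read-out heavily from either starting point.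

Compound 4 `CCOC(=O)N1CCN(C(=O)c2nc(Nc3cc(C4CC4)[nH]n3)c3cc(Cl)ccc3n2)C[C@H]1C` is not yet measured. It differs from compound 3 by methyl in place of ((tert-butyl)carbonyl)oxy on a saturated chain carbon bound to an oxygen next to a carbonyl group. This removes the group whose arrival brought the two large drops. Both steps that bear on the change, a number 65.5 percentage points lower from compound 2 to compound 3 (beyond the scatter) and a number 49.9 percentage points lower from compound 1 to compound 3 (beyond the scatter), were large and downward, so undoing that kind of change is expected to give a large upward step in this assay, back toward the level of compound 2. Compound 4 is therefore expected to show a number 59.9 percentage points higher from compound 3 to compound 4 (beyond the scatter). The estimate for compound 4 in this assay is 84%, with a range from 65% to 97%.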

Compound 4, a percentage reported as inhibition, at one concentration (the size of the read-out at that concentration, not a potency): 79.2%
Beside the measured number, compound 4's estimate is 4.8 percentage points above it, within the range that was stated.
By their numbers in this assay, from the lowest: compound 3; then compounds 1 and 4 (each within the scatter of the next); then compound 2.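

In this assay, the position on a saturated chain carbon bound to an oxygen next to a carbonyl group accepts methyl with a high read-out (a number 55.1 percentage points higher from compound 3 to compound 4 (beyond the scatter)), so the low read-out of compound 3 goes with ((tert-butyl)carbonyl)oxy in particular and not with any group on that carbon. Hydrogen still keeps an edge over methyl (a number 10.4 percentage points lower from compound 2 to compound 4 (beyond the scatter)), while methyl and phenyl cannot be told apart (a number 5.2 percentage points higher from compound 1 to compound 4 (within the scatter)); among the four compounds, therefore, only ((tert-butyl)carbonyl)oxy brings a large drop, and the read-out does not simply fall as the group on that carbon grows from hydrogen through methyl to phenyl. No measurement given here accounts for any of these steps, so their cause remains unknown.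

The compounds shown leave open how a longer chain such as propyl, a branched group such as isopropyl, or a chain ending in an amine or a carboxylic acid would read on that carbon. They also leave open whether the order of stronger and weaker effects seen at this single concentration would hold at other concentrations.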